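The compounds below may be only part of what the source reports. "The series", "measured", "known", "first", "only" and "open" are said of these compounds alone.

Of the compounds shown here, three have so far been measured in a functional assay on A-375 cells (Homo sapiens) for cytotoxicity, read by MTT assay, with a stated time of 48 h; on this read-out lower numbers stand for stronger inhibition and higher numbers for weaker inhibition. Compound 2 `CCOC(=O)/C=C1/C(=O)N2[C@@H]1SC(C)(C)[C@@H]2C(=O)OC(c1ccccc1)c1ccccc1` gives 7000 nM, the lowest number of the three. Compound 1 `CC1(C)[C@H](C(=O)OC(c2ccccc2)c2ccccc2)N2C(=O)/C(=C/C(=O)c3ccc([N+](=O)[O-])cc3)[C@H]2[S+]1[O-]` gives 48200 nM, and compound 3 `CC1(C)[C@H](C(=O)OC(c2ccccc2)c2ccccc2)N2C(=O)/C(=C/C(=O)c3ccc([N+](=O)[O-])cc3)[C@H]2S1(=O)=O` gives 76700 nM; both of these lie beyond the usual scatter from compound 2, so compound 2 is the most potent of the measured set. Within the data shown here, compounds 1 and 3 differ from compound 2 in more than one place, so no single-change step between measured compounds can be read off.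

Compound 4 `CC1(C)S[C@@H]2/C(=C\C(=O)c3ccc(C(F)(F)F)cc3)C(=O)N2[C@H]1C(=O)OC(c1ccccc1)c1ccccc1` is not yet measured. It differs from compound 2 in one place: 4-(trifluoromethyl)phenyl in place of ethoxy on a carbonyl carbon. Cut one bond further out, the change reads ethoxycarbonyl to (4-(trifluoromethyl)phenyl)carbonyl.

Because compound 1 gives 48200 nM and compound 3 gives 76700 nM while both carry an aromatic ring on the corresponding carbonyl, a modest step toward a weaker number is expected, a 2.1-fold higher number from compound 2 to compound 4 (0.33 log units; beyond the scatter), although those two compounds differ from compound 2 in a second place as well. Compound 4 is therefore estimated at 15000 nM, within a range from 5000 nM to 50000 nM.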

Compound 4, half-maximal inhibitory concentration: 26700 nM
Beside the measured number, compound 4's estimate is 1.8-fold (0.25 log units) below it, within the range that was stated.
By their numbers in this assay, from the lowest: compound 2; then compounds 4, 1 and 3 (each within the scatter of the next, the first and the last beyond it).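

In this assay, among these compounds, this is the first change that can be read at a single place: putting 4-(trifluoromethyl)phenyl in place of ethoxy, on a carbonyl carbon whose other neighbour is the double-bonded chain carbon, gives a 3.8-fold higher number from compound 2 to compound 4 (0.58 log units; beyond the scatter). The step is modest, so this carbonyl carbon can carry a much larger group that includes an aromatic ring without the read-out being lost, although ethoxy gives the lower number of this pair. Nothing measured here explains why the number moves with this change.

The compounds shown leave open whether the step comes from the ring itself or from the trifluoromethyl group on it, a question that a plain phenyl at this place would address. On these data alone, how a methyl or an amine on the same carbonyl carbon would compare also remains open.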